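Replacing a Methyl Group on Compound 3's Core

The source may report more compounds than this note shows. Statements on the series, on what has been measured and on what is new or still open speak of the compounds shown alone.

Measured in an ADME assay on BaF3 cells (Mus musculus) for antiproliferative activity, read by CCK-8 assay, with a stated time of 72 h; a higher number here means a weaker inhibitor of growth, a lower number a stronger inhibitor of growth:
- compound 1 `Cc1ccc(NC(=O)CCSc2ccc3c(/C=C/c4ccccn4)n[nH]c3c2)cc1C(F)(F)F`: 530 nM
- compound 2 `Cc1cn(Cc2ccc(NC(=O)CCSc3ccc4c(/C=C/c5ccccn5)n[nH]c4c3)cc2C(F)(F)F)cn1`: 1990 nM
- compound 3 `Cc1n[nH]c2cc(SCCC(=O)Nc3ccc(CN4CCN(C)CC4)c(C(F)(F)F)c3)ccc12`: 3900 nM

The number for compound 3 lies within the scatter of that for compound 2 and beyond the scatter of that for compound 1. Compound 4 `Cc1ccc(-c2n[nH]c3cc(SCCC(=O)Nc4ccc(CN5CCN(C)CC5)c(C(F)(F)F)c4)ccc23)cn1` follows from compound 3 by placing 6-methylpyridin-3-yl in place of methyl on an aromatic carbon.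

Within the data shown here, the only measured single-place step, a 3.8-fold higher number from compound 1 to compound 2 (0.57 log units; beyond the scatter), lies on a saturated chain carbon and so does not test this change. The indirect evidence is that compound 1, at 530 nM, and compound 2, at 1990 nM, also hold a six-membered aromatic ring with 1 hetero atom in their substituent at that carbon. Both also differ from compound 3 elsewhere, so this is weak support. The expected change in this assay is a 3.9-fold lower number from compound 3 to compound 4 (0.59 log units; beyond the scatter), with considerable uncertainty. The estimate for compound 4 is 1000 nM, with an expected range of 250 nM to 4000 nM.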

Compound 4, concentration for 50% growth inhibition: 1180 nM
Compound 4: middle estimate off by 1.2-fold (0.07 log units), on the low side, within the range that was stated.
By their numbers in this assay, from the lowest: compound 1; then compounds 4, 2 and 3 (each within the scatter of the next, the first and the last beyond it).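

In this assay, among these compounds, 6-methylpyridin-3-yl in place of methyl gives a 3.3-fold lower number from compound 3 to compound 4 (0.52 log units; beyond the scatter) and is the first direct test of a change on this aromatic carbon, next to the ring nitrogen. The step shows that this carbon can carry a six-membered aromatic ring with 1 hetero atom and that the number falls rather than rises, whereas compound 1 and compound 2 held such a ring there only alongside differences elsewhere. No measurement shown gives a reason for this step.

The compounds shown leave open whether the step depends on the ring nitrogen or on the methyl of the new ring, which a plain phenyl ring or an unsubstituted pyridin-3-yl at this carbon would separate. Also open, going by these compounds, is how an amine or a carboxylic acid on that ring would read.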